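Acylsulfonamide side chains and rat liver microsome stability

The compounds below may be only part of what the source reports. "The series", "measured", "known", "first", "only" and "open" are said of these compounds alone.

Measured compounds:
- compound 1 `CC(C)OC(=O)NCCS(=O)(=O)NC(=O)c1ccc(Nc2nc(NC3(c4ccc(Cl)cc4)CC3)nc(OCC(F)(F)F)n2)cc1`: 73%
- compound 2 `O=C(NS(=O)(=O)c1ccccc1)c1ccc(Nc2nc(NC3(c4ccc(Cl)cc4)CC3)nc(OCC(F)(F)F)n2)cc1`: 100%
- compound 3 `CC(C)S(=O)(=O)NC(=O)c1ccc(Nc2nc(NC3(c4ccc(Cl)cc4)CC3)nc(OCC(F)(F)F)n2)cc1`: 96%

Three compounds sharing one core were tested in an ADME assay on microsomes from liver (Rattus norvegicus) for metabolic stability, with a stated time of 10 min; on this read-out lower numbers stand for a less stable compound and higher numbers for a more stable compound. Compound 2 gives 100%, the highest of the three numbers. Compound 3 sits nearest, and the step of a number 4 percentage points lower from compound 2 to compound 3 (within the scatter) is within the scatter, so the two cannot be told apart. Compound 1, with a longer side chain on the sulfonyl sulfur, gives 73%, and the steps of a number 27 percentage points higher from compound 1 to compound 2 (beyond the scatter) and a number 23 percentage points higher from compound 1 to compound 3 (beyond the scatter) are both beyond the scatter.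

The new compound 4 `CCS(=O)(=O)NC(=O)c1ccc(Nc2nc(NC3(c4ccc(Cl)cc4)CC3)nc(OCC(F)(F)F)n2)cc1` differs from compound 2 in one place: ethyl in place of phenyl on a sulfonyl sulfur.

Within the data shown here, the step that bears most directly on this change is the one from compound 2 to compound 3, where an isopropyl replaced the phenyl on the same sulfonyl sulfur and the number moved only within the scatter. Ethyl is another short alkyl group at that position, so no step beyond the scatter is expected here. Compound 4 is therefore estimated at 94%, with a range of 82% to 100%, meaning an expected step of a number 6 percentage points lower from compound 2 to compound 4 (within the scatter).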

Compound 4, percent of the compound remaining: 85%
Estimate against measurement, compound 4: 9 percentage points above; measured number inside the range.
By their numbers in this assay, from the lowest: compound 1; then compound 4; then compounds 3 and 2 (each within the scatter of the next).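

In this assay, the sulfonyl sulfur proves sensitive to the choice of short alkyl group: ethyl in place of phenyl gives a number 15 percentage points lower from compound 2 to compound 4 (beyond the scatter), although isopropyl in place of phenyl had stayed within the scatter. Going from isopropyl to ethyl, with hydrogen in place of methyl on the saturated chain carbon bound to the sulfonyl sulfur, gives a number 11 percentage points lower from compound 3 to compound 4 (beyond the scatter), so the loss of a single methyl is enough to register at this position. Ethyl still keeps an advantage over the much longer side chain, with a number 12 percentage points higher from compound 1 to compound 4 (beyond the scatter), which means that a short alkyl group alone does not settle the number, yet both short alkyl groups remain ahead of that chain.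

Nothing shown here explains why ethyl and isopropyl part in this way. Still open, from the compounds shown here alone, is where methyl, cyclopropyl or a straight propyl chain on the sulfonyl sulfur would fall, and whether a substituted phenyl would hold the number seen with plain phenyl.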